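Swapping Phenyl for Furan-3-yl in a Tolerated Compound

A few compounds are considered here, and "the series" means these few. Any claim that something is new, unique, unknown or untested is made for them only; others in the source may bear on it.

Compound 3 `CCCCCCCCCCCCCCCCCCOP(=O)(O)OC[C@H]1O[C@@H](n2ccc3c(-c4ccccc4)ncnc32)[C@H](O)[C@@H]1O` gives > 50000 nM in an ADME assay on MRC5 cells (Homo sapiens) for cytotoxicity, read by MTT assay, with a stated time of 72 h (a lower number here means that less compound is tolerated, a higher number that more compound is tolerated), and this is a limit of the assay and not a number. Compound 2 `OC[C@H]1O[C@@H](n2cc(Cl)c3c(-c4cccs4)ncnc32)[C@H](O)[C@@H]1O` gives > 50000 nM, which is likewise a limit. From the compounds shown here alone, compound 3 therefore stands at the limit of > 50000 nM in this assay, at which 2 of the 3 values shown sit, and its true distance from the other compounds is unknown. Going by the values given here, the only value in this assay that is a number belongs to compound 1 `OC[C@H]1O[C@@H](n2cc(F)c3c(-c4ccoc4)ncnc32)[C@H](O)[C@@H]1O`, at 15400 nM.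

Compound 4 `CCCCCCCCCCCCCCCCCCOP(=O)(O)OC[C@H]1O[C@@H](n2ccc3c(-c4ccoc4)ncnc32)[C@H](O)[C@@H]1O` differs from compound 3 in one place, with furan-3-yl in place of phenyl on an aromatic carbon. Among the compounds with values here, no measured pair isolates this exchange, so the expectation rests on thin ground. Compound 1 also carries furan-3-yl and gives 15400 nM, but it differs from compound 4 elsewhere as well. A moderate step toward a lower number is therefore expected, although compound 4 may well stay at the limit. The estimated change is an at least 1.4-fold lower number from compound 3 to compound 4 (0.15 log units; that floor lies within the scatter). For compound 4 the expected half-maximal cytotoxic concentration is 35000 nM, with an estimated range from 10000 nM to 50000 nM.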

Compound 4, half-maximal cytotoxic concentration: > 50000 nM
Compound 4 was reported as a limit; the forecaster's own chance of this, stated with the estimate: 45%; at least 1.4-fold (0.15 log units) between middle value and limit.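

Compound 4, like compound 3, is reported only as a limit in this assay, and no step between the two can be read: the limit of > 50000 nM in this assay, at which 3 of the 4 values shown sit.

The compounds shown leave open whether furan-3-yl in place of phenyl on an aromatic carbon changes the half-maximal cytotoxic concentration at all, and by how much.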